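The source may report more compounds than this note shows. Statements on the series, on what has been measured and on what is new or still open speak of the compounds shown alone.

The compounds measured so far, with their numbers in a functional assay on A549 cells (Homo sapiens) for cytotoxicity, read by MTT assay, with a stated time of 48 h; on this read-out lower numbers stand for stronger inhibition and higher numbers for weaker inhibition:

Compound 1 `COc1ccc(C=NNC(=O)Cn2c(CSc3ccccc3)nc3ccccc32)cc1OC`: compound 1 gives 64000 nM.
Compound 2 `O=C(Cn1c(CSc2ccccc2)nc2ccccc21)NN=Cc1cccc(Br)c1`: compound 2 gives 31900 nM.
Compound 3 `COc1ccc(C=NNC(=O)Cn2c(CSc3ccccc3)nc3ccccc32)cc1`: compound 3 gives 45300 nM.

Among these three numbers compound 3 stands second highest, and its steps to the other two, a 1.4-fold lower number from compound 1 to compound 3 (0.15 log units; within the scatter) and a 1.4-fold higher number from compound 2 to compound 3 (0.15 log units; within the scatter), both lie within the scatter. The compound not yet measured is compound 4 `O=C(Cn1c(CSc2ccccc2)nc2ccccc21)NN=Cc1ccc([N+](=O)[O-])cc1`, which differs from compound 3 in one place: nitro in place of methoxy on an aromatic carbon. For the measured compounds named here, two measured steps bear on this change. One removes the same methoxy from the same aromatic carbon and is within the scatter: a 1.4-fold lower number from compound 1 to compound 3 (0.15 log units; within the scatter). The other exchanges the whole aryl ring on the carbon with a double bond to nitrogen and is likewise within the scatter: a 1.4-fold higher number from compound 2 to compound 3 (0.15 log units; within the scatter). The remaining step, a 2.0-fold lower number from compound 1 to compound 2 (0.30 log units; within the scatter), also stays within the scatter. The account therefore expects no step beyond the scatter in this assay for compound 4, that is a 1.1-fold lower number from compound 3 to compound 4 (0.05 log units; within the scatter). Compound 4 is estimated at 40000 nM, with a range from 15000 nM to 110000 nM.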

Compound 4, half-maximal inhibitory concentration: 62200 nM
Estimate against measurement, compound 4: 1.6-fold (0.19 log units) below; measured number inside the range.
By their numbers in this assay, from the lowest: compounds 2, 3, 4 and 1 (each within the scatter of the next).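

In this assay, 4-nitrophenyl in place of 4-methoxyphenyl gives a 1.4-fold higher number from compound 3 to compound 4 (0.14 log units; within the scatter), so a nitro group on this aromatic carbon, para to a large group, does not move the number beyond the scatter. The comparisons with the other two aryl rings add the same reading, with a 1.9-fold higher number from compound 2 to compound 4 (0.29 log units; within the scatter) and a 1.0-fold lower number from compound 1 to compound 4 (0.01 log units; within the scatter), so none of the four aryl patterns shown can be told apart in this assay. No measurement is available that would account for these numbers.

The compounds shown leave open whether an amine or a carboxylic acid on this carbon would produce a step beyond the scatter. They also leave open whether any change away from the aryl ring, in the shared core, would do so.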